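The source may hold more compounds than are shown below. What is called first, only, known or untested is meant among the compounds shown, and "the series" means these compounds.

Measured in a functional assay on PC-3 cells (Homo sapiens) for inhibition, read by MTT assay, with a stated time of 48 h, tested at 10 uM; on this read-out lower numbers stand for less inhibition of growth and higher numbers for more inhibition of growth at the one concentration tested:

Compound 1 `CCOC(=O)N1CCN(Cc2c(O)c([C@H]3CCN(C)C[C@H]3O)c3oc(C)cc(=O)c3c2O)CC1`: 1%
Compound 2 `Cc1oc2c([C@H]3CCN(C)C[C@H]3O)c(O)cc(O)c2c(=O)c1C(O)c1c(Cl)cccc1Cl`: 0%

Compound 2, at 0%, lies within the usual scatter of compound 1, and neither compound shows much inhibition of growth at the concentration tested. Compound 3 `Cc1oc2c([C@H]3CCN(C)C[C@H]3O)c(O)cc(O)c2c(=O)c1C(O)c1ccc(F)cc1` differs from compound 2 in one group: 4-fluorophenyl in place of 2,6-dichlorophenyl on a saturated chain carbon bound to an aromatic carbon and an oxygen on a saturated carbon. The 4-fluorophenyl takes the place of the 2,6-dichlorophenyl on a saturated chain carbon bound to an aromatic carbon and an oxygen on a saturated carbon. Within the data shown here, no measured pair yet shows what this change does in this assay. Among the measured compounds shown here, the only guide is that compound 1, which carries different groups on the shared core, gives 1%. The expected size of the step, a number 4 percentage points higher from compound 2 to compound 3 (within the scatter), is small, with at most a slight rise and probably nothing beyond the scatter. For compound 3 the estimated value is 4%, with an expected range of 0% to 15%.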

Compound 3, percent growth inhibition at one concentration: 0%
Estimate against measurement, compound 3: 4 percentage points above; low and high end bracket the measured number.
By their numbers in this assay, from the lowest: compounds 2, 3 and 1 (each within the scatter of the next).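

In this assay, among these compounds, the one direct comparison at this position, 4-fluorophenyl in place of 2,6-dichlorophenyl on a saturated chain carbon bound to an aromatic carbon and an oxygen on a saturated carbon, gives no change at the digits printed from compound 2 to compound 3 (within the scatter). This exchange of one halogen-bearing phenyl for another therefore leaves the read-out unmoved, and with almost no inhibition of growth on either side, the pair cannot reveal any difference between the two groups that might appear under other conditions. No supporting measurement bears on why this is so.

Going by these compounds, whether an unsubstituted phenyl, an amine or a carboxylic acid at this carbon would produce measurable inhibition of growth remains open. Among the compounds shown here, compound 1 forms no single-change step with either of the other compounds, so its different groups cannot be read against them.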